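Nitrile to tetrazole on the chain of compound 1

The source may report more compounds than this note shows. Statements on the series, on what has been measured and on what is new or still open speak of the compounds shown alone.

Measured compounds:
compound 1, `CCc1cc(C(C)=O)c(O)cc1OCCCCC#N`, 92%
compound 2, `CC(=O)c1cc(C(C)=O)c(OCCCCC#N)cc1O`, 8%

Among the measured compounds shown here, in an assay on isolated protein for inhibition of leukotriene B4 receptor 1 (Homo sapiens), tested at 10 uM (a higher number here means more inhibition at the concentration tested (going by the name of the read-out), a lower number less inhibition), compound 1 gives 92%, the higher of the two numbers known. Compound 2, which carries acetyl in place of ethyl on an aromatic carbon, gives 8%, and the step of a number 84 percentage points lower from compound 1 to compound 2 (beyond the scatter) is large. Compound 3, `CCc1cc(C(C)=O)c(O)cc1OCCCCCCc1nnn[nH]1`, differs from compound 1 elsewhere: 2-(1H-tetrazol-5-yl)ethyl in place of cyano on a saturated chain carbon, four bonds along the chain from an oxygen on an aromatic ring. For the measured compounds named here, the only measured step concerns a different place on the core of compound 1 and does not bear on this chain change, so no measured step guides the expectation. The ethyl and acetyl groups of compound 1 are kept in compound 3, and the chain still ends in a group that counts as a hydrogen-bond acceptor. Compound 3 is therefore expected to stay near compound 1, with a step of a number 8 percentage points lower from compound 1 to compound 3 (within the scatter) in this assay. The estimate for compound 3 is 84%, in the range 55% to 100%.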

Compound 3, a percentage reported as inhibition, at one concentration (the size of the read-out at that concentration, not a potency): 91%
For compound 3 the middle estimate is 7 percentage points below the measured one; low and high end bracket the measured number.
By their numbers in this assay, from the lowest: compound 2; then compounds 3 and 1 (each within the scatter of the next).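

In this assay, the chain end of compound 1 proves open to a large exchange, with a number 1 percentage points lower from compound 1 to compound 3 (within the scatter). Among the compounds shown here, at this saturated chain carbon, four bonds along the chain from an oxygen on an aromatic ring, 2-(1H-tetrazol-5-yl)ethyl with its 7 heavy atoms, five-membered aromatic ring and hydrogen-bond donor takes the place of the 2 heavy atoms of cyano, whereas the one change on an aromatic carbon gave a number 84 percentage points lower from compound 1 to compound 2 (beyond the scatter). No measurement at hand explains why the nitrile and the tetrazole chain ends read alike.

Going by these compounds, since the read-out is a percentage at one concentration and not a potency, any difference in potency between the two remains open. Also open, on these data alone, is whether a carboxylic acid or an amine at the chain end, or a shorter chain carrying the tetrazole, would hold the read-out as well.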